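This account rests on a few compounds, and the source may have more. Where it says the series, first, only, none or still open, it means among the compounds named here.

Compound 1 `CCCCn1c(Cc2cc(OC)c(OC)c(OC)c2)nc2c(N)nc(F)nc21`: 185000000 nM
Compound 2 `C=CCCn1c(Cc2cc(OC)c(OC)c(OC)c2)nc2c(N)nc(F)nc21`: 102000000 nM
Compound 3 `CC#CCCn1c(Cc2cc(OC)c(OC)c(OC)c2)nc2c(N)nc(F)nc21`: 95500000 nM

These three compounds share a core and differ only in the chain on the aromatic nitrogen. In a functional assay on MCF7 cells (Homo sapiens) for cytotoxicity (a higher number here means that more compound is needed for the effect, a lower number that less compound is needed), compound 1 gives 185000000 nM. Within the data shown here, its distance to the other two is small: the step of a 1.8-fold lower number from compound 1 to compound 2 (0.26 log units; within the scatter) and the step of a 1.9-fold lower number from compound 1 to compound 3 (0.29 log units; within the scatter) both lie within the scatter, as does the step of a 1.1-fold lower number from compound 2 to compound 3 (0.03 log units; within the scatter), so no compound of the three is set apart from the others.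

Compound 4 `COc1cc(Cc2nc3c(N)nc(F)nc3n2CC2CCC2)cc(OC)c1OC` has not yet been measured in this assay. It differs from compound 1 as follows: cyclobutyl in place of propyl on a saturated chain carbon bound to an aromatic nitrogen. Among the measured compounds shown here, no measured step closes a ring; the measured steps only exchange the chain terminus, and each of them stayed within the scatter. On that basis a step from compound 1 to compound 4 in this assay that stays within the scatter is expected, in no particular direction, as a 1.2-fold lower number from compound 1 to compound 4 (0.09 log units; within the scatter). Compound 4 is therefore estimated at 150000000 nM, with a range from 60000000 nM to 400000000 nM.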

Compound 4, half-maximal effective concentration: 109000000 nM
For compound 4 the middle estimate is 1.4-fold (0.14 log units) above the measured one, within the range that was stated.
By their numbers in this assay, from the lowest: compounds 3, 2, 4 and 1 (each within the scatter of the next).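

Setting a cyclobutyl ring at this place, which none of the open chains of compounds 1 to 3 carries, still leaves this assay within the scatter, with the step of a 1.7-fold lower number from compound 1 to compound 4 (0.23 log units; within the scatter) as the result. The ring is not set apart from the other chains either, since the step of a 1.1-fold higher number from compound 2 to compound 4 (0.03 log units; within the scatter) and the step of a 1.1-fold higher number from compound 3 to compound 4 (0.06 log units; within the scatter) both lie within the scatter as well, so the four chain ends shown on a saturated chain carbon bound to an aromatic nitrogen cannot be told apart here. No supporting evidence bearing on this result is at hand.

Going by these compounds, it stays open whether a larger ring such as cyclohexyl, an amine or a carboxylic acid at the chain end would give a step beyond the scatter. On these data alone, whether a change elsewhere on the shared core would do so also stays open.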